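This account rests on a few compounds, and the source may have more. Where it says the series, first, only, none or still open, it means among the compounds named here.

Three related amides have been tested in an ADME assay on BJ cells (Homo sapiens) for cytotoxicity, read by CellTiter-Glo and resazurin assay, with a stated time of 72 h; a higher number here means that more compound is needed for the effect, a lower number that less compound is needed. Compound 1 `CC(C)N(Cc1cccc(OCCCCCC(=O)O)c1)C(=O)c1ccc(-c2ccsc2)cc1` gives only a limit of the assay there, > 26000 nM. Compound 2 `CC(C)N(Cc1cccc(OCCCCCC(=O)O)c1)C(=O)c1ccc(-c2cccc(Cl)c2)cc1` likewise gives only a limit, > 21900 nM. Compound 3 `CCOC(=O)CCCCCOc1cccc(CN(C(=O)c2ccc(-c3cccnc3)cc2)C(C)C)c1` also stands at a limit, > 26000 nM. The single step among these three, a step that the two limits leave unreadable from compound 1 to compound 2, cannot be read; both of its ends are limits. The two limits in question are the limit of > 21900 nM in this assay, at which 1 of the 3 values shown sits, and (the limit of > 26000 nM in this assay, at which 2 of the 3 values shown sit).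

Compound 4 `CCOC(=O)CCCCCOc1cccc(CN(C(=O)c2ccc(-c3ccc4c(c3)OCCO4)cc2)C(C)C)c1` differs from compound 3 in one place (2,3-dihydro-1,4-benzodioxin-6-yl in place of pyridin-3-yl on an aromatic carbon). Among the measured compounds shown here, no measured step in this set bears on this particular change, and no measured step in this set has a readable size; every value in this assay here is a limit. The expectation for compound 4 therefore rests only on that picture: compound 4 is expected to give 26000 nM, within 13000 nM to 60000 nM. The step that this estimate means, a number no higher from compound 3 to compound 4 (the limit leaves the size open), is expected to stay within the scatter, most likely as another limit rather than a number.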

Compound 4, half-maximal effective concentration: > 24400 nM
Compound 4: a limit, no number; the forecaster's own chance of this, stated with the estimate: 85%; the middle value is on the limit's open side.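

In this assay compound 4 gives only a limit, > 24400 nM. Among the compounds shown here, compound 3 also stands at a limit, so no step between compound 3 and compound 4 can be read. All four compounds shown stop at limits, leaving open what concentration any of them needs for the half-maximal effect.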